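Methyl for Methoxy on the Urea Aryl Group

The compounds below may be only part of what the source reports. "The series", "measured", "known", "first", "only" and "open" are said of these compounds alone.

Compound 1 `COc1ccc(NC(=O)Nc2cccc(CNc3nccnc3Cl)c2)cc1` is one of three ureas built on a shared core. In a functional assay on HepG2 cells (Homo sapiens) for antiproliferative activity, read by MTT assay, with a stated time of 48 h (a lower number here means a stronger inhibitor, a higher number a weaker inhibitor), compound 1 gives 12000 nM, the highest of the three numbers, although every difference among them lies within the scatter. Compound 2 `O=C(Nc1cccc(Cl)c1)Nc1cccc(CNc2nccnc2Cl)c1` gives 9140 nM, and compound 3 `O=C(Nc1cccc(CNc2nccnc2Cl)c1)Nc1ccc(F)c(Cl)c1` gives 6750 nM. The steps of a 1.3-fold lower number from compound 1 to compound 2 (0.12 log units; within the scatter) and a 1.8-fold lower number from compound 1 to compound 3 (0.25 log units; within the scatter) both stay within the scatter, as does a 1.4-fold lower number from compound 2 to compound 3 (0.13 log units; within the scatter). Compound 4 `Cc1ccc(NC(=O)Nc2cccc(CNc3nccnc3Cl)c2)cc1` differs from compound 1 by methyl in place of methoxy on an aromatic carbon. Within the data shown here, no measured step swaps these two groups; the nearest comparisons, in which other aryl groups replaced 4-methoxyphenyl, moved the number only within the scatter. A change of that size is therefore expected, a 1.1-fold lower number from compound 1 to compound 4 (0.04 log units; within the scatter), with no clear direction. Compound 4 is estimated at 11000 nM, between 5000 nM and 25000 nM.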

Compound 4, half-maximal inhibitory concentration: 11500 nM
Compound 4: the middle estimate sits 1.0-fold (0.02 log units) below what was measured; low and high end bracket the measured number.
By their numbers in this assay, from the lowest: compounds 3, 2, 4 and 1 (each within the scatter of the next).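

In this assay, the swap of methoxy for methyl on the aromatic carbon para to a large group is now read directly, as a 1.0-fold lower number from compound 1 to compound 4 (0.02 log units; within the scatter) shows, so removing the oxygen and its one hydrogen-bond acceptor leaves the number within the scatter. The 4-methylphenyl group also stays within the scatter of the two chlorinated aryl groups, with a 1.7-fold higher number from compound 3 to compound 4 (0.23 log units; within the scatter) and with a 1.3-fold higher number from compound 2 to compound 4 (0.10 log units; within the scatter) as well. No supporting measurement accounts for these small differences. On these data alone, whether an amine or a carboxylic acid at this position would move the number beyond the scatter remains open.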